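A few compounds are considered here, and "the series" means these few. Any claim that something is new, unique, unknown or untested is made for them only; others in the source may bear on it.

Going by the values given here, in a functional assay on L1210 cells (Mus musculus) for inhibition (a higher number here means a weaker inhibitor, a lower number a stronger inhibitor), compound 3 `C=Cc1cc(O)nc(O)n1` gives 3000 nM, the only true number among the three compounds measured. Compound 1 `CCOC(=O)/C=C/c1cc(=O)[nH]c(=O)n1C1O[C@H](CO)[C@@H](O)[C@H]1O` reaches only a limit, > 35000 nM. Compound 2 `CCOC(=O)/C(C)=C/c1cc(=O)[nH]c(=O)n1C1O[C@H](CO)[C@@H](O)[C@H]1O` also reaches only a limit, > 30000 nM. Compound 4 `C=Cc1nc(O)nc(O)c1I` carries iodo in place of hydrogen on an aromatic carbon of compound 3, ortho to the vinyl group (iodo in place of hydrogen on an aromatic carbon). Among the compounds with values here, the one measured step, a step that the two limits leave unreadable from compound 1 to compound 2, has no readable size and changes a different group, so no measured step bears on adding iodo. With no guide for either direction, the expected result is no clear shift beyond the scatter, and the estimated step is a 1.3-fold higher number from compound 3 to compound 4 (0.12 log units; within the scatter). For compound 4 the estimate is 4000 nM, with an expected range of 800 nM to 20000 nM.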

Compound 4, half-maximal inhibitory concentration: 2000 nM
Compound 4: the middle estimate sits 2.0-fold (0.30 log units) above what was measured, and the stated range covers the measured number.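

In this assay, iodo in place of hydrogen gives a 1.5-fold lower number from compound 3 to compound 4 (0.18 log units; within the scatter) and this is the first readable step among these compounds. It shows that, on this aromatic carbon ortho to a vinyl group, one iodine atom brings no shift that can be told from the scatter, so the result of this change is a flat step rather than a gain or a loss. Going by these compounds, only hydrogen and iodo are compared at this position, so how an amine or a carboxylic acid would read there remains open. Nothing in the data shown bears on why this step is so small.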